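The source may report more compounds than this note shows. Statements on the series, on what has been measured and on what is new or still open speak of the compounds shown alone.

Compound 2 `CCOC(=O)N1CCC(N(Cc2cc(Cl)ccc2O)C(=O)N(C)C)CC1` gives the highest number of the three measured in a functional assay on K562 cells (Homo sapiens) for antiproliferative activity, read by MTT assay, with a stated time of 48 h (a higher number here means a weaker inhibitor, a lower number a stronger inhibitor), at 38400 nM; compound 1 `CCOC(=O)N1CCC(N(Cc2cccc([N+](=O)[O-])c2)C(=O)N(C)C)CC1` gives 26000 nM in this assay, and compound 3 `CN(C)C(=O)N(Cc1ccc(O)cc1)Cc1ccco1` gives 18600 nM. Compound 4 `CCOC(=O)N1CCC(N(Cc2ccc(O)cc2)C(=O)N(C)C)CC1` differs from compound 2 by 4-hydroxyphenyl in place of 5-chloro-2-hydroxyphenyl on a saturated chain carbon bound to an amide-type nitrogen. Among the measured compounds shown here, the one measured step at this position, a 1.5-fold higher number from compound 1 to compound 2 (0.17 log units; within the scatter), is the only direct guide; compound 3 carries the entering group but on a different core, so its value shows only that the entering group sits on a compound with a lower number. A small step is therefore expected, if anything toward a lower number. Compound 4 is estimated at 25000 nM, between 10000 nM and 60000 nM, an expected step of a 1.5-fold lower number from compound 2 to compound 4 (0.19 log units; within the scatter).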

Compound 4, half-maximal inhibitory concentration: 41800 nM
For compound 4 the middle estimate is 1.7-fold (0.22 log units) below the measured one; the measured number falls inside the stated range.
By their numbers in this assay, from the lowest: compounds 3, 1, 2 and 4 (each within the scatter of the next, the first and the last beyond it).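

In this assay, 4-hydroxyphenyl in place of 5-chloro-2-hydroxyphenyl on a saturated chain carbon bound to an amide-type nitrogen gives a 1.1-fold higher number from compound 2 to compound 4 (0.04 log units; within the scatter) and so does not separate the two groups, while 4-hydroxyphenyl in place of 3-nitrophenyl gives a 1.6-fold higher number from compound 1 to compound 4 (0.21 log units; within the scatter) and likewise stays inside the scatter. On the shared core, all three groups at this position therefore read alike, with no order among them. Nothing available bears on why this position reads so flat.

On these data alone, whether an aminophenyl or carboxyphenyl group, or a longer chain at this position, would shift the number beyond the scatter remains open.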